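The compounds below may be only part of what the source reports. "The series", "measured", "known", "first", "only" and "open" are said of these compounds alone.

Measured so far:
compound 1 `NS(=O)(=O)c1ccc(/N=C2\NC(=O)/C(=C3/C(=O)Nc4ccc(F)cc43)S2)cc1` — 20500 nM in a functional assay on MCF7 cells (Homo sapiens) for antiproliferative activity, read by MTT assay; a higher number here means a weaker inhibitor, a lower number a stronger inhibitor
compound 2 `Cc1cc(C)c2c(c1)/C(=C1/S/C(=N/c3ccc(S(N)(=O)=O)cc3)NC1=O)C(=O)N2` — > 200000 nM in this assay, a limit

Among the compounds with values here, compound 1 supplies the only numerical value in this assay. Compound 2 reaches only (the limit of > 200000 nM in this assay, at which 1 of the 2 values shown sits), which is a limit of the assay rather than a number. Compound 3 `COc1ccc2c(c1)/C(=C1/S/C(=N/c3ccc(S(N)(=O)=O)cc3)NC1=O)C(=O)N2` differs from compound 1 by methoxy in place of fluoro on an aromatic carbon. Within the data shown here, no measured step of this kind exists to lean on. The change is expected to weaken inhibition by about a 2.2-fold higher number from compound 1 to compound 3 (0.34 log units; beyond the scatter), somewhat beyond the scatter. Compound 3 is therefore estimated at 45000 nM, with a range from 12000 nM to 200000 nM.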

Compound 3, half-maximal inhibitory concentration: 125000 nM
Beside the measured number, compound 3's estimate is 2.8-fold (0.44 log units) below it; the range from low to high includes it.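

Putting methoxy in place of fluoro on this aromatic carbon weakens inhibition in this assay, with a 6.1-fold higher number from compound 1 to compound 3 (0.79 log units; beyond the scatter). Within the data shown here, this gives the first measured step at this position and shows that the group it carries matters, since the step lies beyond the scatter. Nothing shown here accounts for the size of this step.

As far as these compounds go, whether an amine, a hydroxyl or plain hydrogen on this carbon would keep the inhibition of compound 1 remains open. A single step also cannot show how inhibition follows the choice of group here.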